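Swapping a Furan for a Thiophene Where Nothing Has Moved Yet

This account rests on a few compounds, and the source may have more. Where it says the series, first, only, none or still open, it means among the compounds named here.

Of the compounds shown here, two built on one shared core have so far been tested in a functional assay on Ehrlich cells (Mus musculus) for cytotoxicity, read by trypan blue exclusion, with a stated time of 2 h, tested at 10 ug/mL; a higher number here means a stronger effect of the compound at the concentration tested, a lower number a weaker effect. Compound 1 `N#CC1=C(N)N(c2ccc(S(N)(=O)=O)cc2)C2=C(CCCC2)C1c1ccc(Cl)cc1Cl` carries a 2,4-dichlorophenyl group on a saturated ring carbon, and in this assay compound 1 gives 0%. Compound 2 `Cc1ccc(C2C(C#N)=C(N)N(c3ccc(S(N)(=O)=O)cc3)C3=C2CCCC3)o1` carries a 5-methylfuran-2-yl group in place of that aryl group, and in this assay compound 2 gives 0%. Going by the values given here, the single measured step, no change at the digits printed from compound 1 to compound 2 (within the scatter), shows that exchanging one aromatic group for a quite different one on that carbon left the read-out where it was. Compound 2 therefore stands level with compound 1, both at the floor of the read-out.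

Compound 3 `N#CC1=C(N)N(c2ccc(S(N)(=O)=O)cc2)C2=C(CCCC2)C1c1cccs1` has not yet been measured. It differs from compound 2 as follows: thiophen-2-yl in place of 5-methylfuran-2-yl on a saturated ring carbon. Among the compounds with values here, the only step that bears on this change is the earlier one on the same saturated ring carbon, which was flat within the scatter. On that basis the expected step is no change at the digits printed from compound 2 to compound 3 (within the scatter). Compound 3 is therefore estimated to give 0%, with a range from 0% to 12%.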

Compound 3, a percentage reported as activity, at one concentration (the size of the read-out at that concentration, not a potency): 0%
Compound 3: middle estimate and measured number agree at the digits printed, and the stated range covers the measured number.
By their numbers in this assay, from the lowest: compounds 1, 2 and 3 (each within the scatter of the next).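

In this assay the step of no change at the digits printed from compound 2 to compound 3 (within the scatter) adds a ring with sulfur as its hetero atom to the groups tried on this saturated ring carbon, where until now only a phenyl ring and a ring with oxygen had been read. The step of no change at the digits printed from compound 1 to compound 3 (within the scatter) extends the same picture to a direct exchange of 2,4-dichlorophenyl for thiophen-2-yl, so all three aromatic groups, 2,4-dichlorophenyl, 5-methylfuran-2-yl and thiophen-2-yl, now read alike, at the floor of the scale, where a change that weakened the effect could not show. Nothing available here offers a reason for this flat reading.

Still open, as far as these compounds go, is whether any group on this carbon can lift the read-out off the floor at all, for instance a cyclohexyl ring or a short alkyl chain in place of the aromatic ring, or a phenyl ring carrying an amine or a carboxylic acid. Equally open, from the compounds shown here alone, is whether a change elsewhere on the shared core, such as exchanging the nitrile for an amide, would move the read-out when this carbon does not.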